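A few compounds are considered here, and "the series" means these few. Any claim that something is new, unique, unknown or untested is made for them only; others in the source may bear on it.

Compound 1, `CCCN1CC[C@@]2(OC)OC(N)=C(C#N)[C@@H](c3ccc(Cl)cc3)[C@@H]2C1`: in a functional assay on trachea (Cavia porcellus) (a higher number here means a weaker inhibitor, a lower number a stronger inhibitor), compound 1 gives 30300 nM.
Compound 2, `CCCN1CC[C@@]2(OC)OC(N)=C(C#N)[C@@H](c3ccc(Cl)cc3Cl)[C@@H]2C1`: in this assay compound 2 gives 35500 nM.
Compound 3, `CO[C@@]12CCN(C)C[C@H]1[C@H](c1ccc(C)cc1)C(C#N)=C(N)O2`: in this assay compound 3 gives 13200 nM.

Of these three numbers, compound 3 has the lowest, which in this assay means the strongest inhibition of the three. Compound 1 stands nearest to it and compound 2 furthest, and both gaps lie beyond the scatter of repeated measurements.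

Going by the values given here, only one measured step joins two compounds that differ in a single place: a 1.2-fold higher number from compound 1 to compound 2 (0.07 log units; within the scatter), where a chloro replaces a hydrogen on an aromatic carbon.

Compound 4, `CCCN1CC[C@@]2(OC)OC(N)=C(C#N)[C@@H](c3ccc(C)cc3)[C@@H]2C1`, differs from compound 3 by ethyl in place of hydrogen on a saturated chain carbon bound to an amine nitrogen in a ring. Among the compounds with values here, no measured step touches this place; the one measured step concerns the aromatic ring, not the group on the ring nitrogen, so it offers no guide to the size or direction of this change. With nothing to point either way, the expected step is a 1.0-fold lower number from compound 3 to compound 4 (0.01 log units; within the scatter), no change beyond the scatter, held with a wide range.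

Compound 4 is therefore estimated at 13000 nM in this assay, expected to fall between 4000 nM and 45000 nM.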

Compound 4, half-maximal inhibitory concentration: 21000 nM
The estimate for compound 4 lay 1.6-fold (0.21 log units) below the measured number; the range from low to high includes it.
By their numbers in this assay, from the lowest: compounds 3, 4, 1 and 2 (each within the scatter of the next, the first and the last beyond it).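

Putting ethyl in place of hydrogen on a saturated chain carbon bound to an amine nitrogen in a ring, which turns methyl into propyl, gives a 1.6-fold higher number from compound 3 to compound 4 (0.20 log units; within the scatter) in this assay, so this longer chain brings no change that can be told from the scatter. With propyl in place, methyl in place of chloro on an aromatic carbon gives a 1.4-fold lower number from compound 1 to compound 4 (0.16 log units; within the scatter), and 4-methylphenyl in place of 2,4-dichlorophenyl on a saturated ring carbon gives a 1.7-fold lower number from compound 2 to compound 4 (0.23 log units; within the scatter), so neither aromatic change stands out from the scatter either. No measurement at hand offers an explanation for these small steps.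

Methyl and propyl are the only groups shown on this amine nitrogen, so the outcome with a longer chain such as hexyl, or with a benzyl group, remains open. A methoxy group on the aromatic ring is also untested by these compounds.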